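A few compounds are considered here, and "the series" means these few. Any claim that something is new, unique, unknown or untested is made for them only; others in the source may bear on it.

Of the compounds shown here, three have been measured in an ADME assay on tissue (MIA PaCa-2 cells, Homo sapiens) for pharmacokinetics; on this read-out lower numbers stand for a shorter-lived compound and higher numbers for a longer-lived compound. Compound 3 `N[C@@H](CCC(=O)OC[C@H]1O[C@@H](n2cc(F)c(=O)[nH]c2=O)C[C@@H]1O)C(=O)O` gives 0.335 h in this assay. Compound 1 `N[C@@H](CC(=O)OC[C@H]1O[C@@H](n2cc(F)c(=O)[nH]c2=O)C[C@@H]1O)C(=O)O` differs from compound 3 by amino(carboxy)methyl in place of 2-amino-2-carboxyethyl on a saturated chain carbon bound to a carbonyl carbon, and in this assay compound 1 gives 0.273 h; the step of a 1.2-fold lower number from compound 3 to compound 1 (0.09 log units; within the scatter) is small. Compound 2 `N[C@@H](CCC(=O)O[C@H]1C[C@H](n2cc(F)c(=O)[nH]c2=O)O[C@@H]1CO)C(=O)O` has the same atoms as compound 3 joined differently, and the difference between the two cores is not broken down here. In this assay compound 2 gives 0.17 h, a value that lies within the scatter of the other two numbers, so no order among the three can be read from them.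

Compound 4 `N[C@@H](CC(=O)O[C@H]1C[C@H](n2cc(F)c(=O)[nH]c2=O)O[C@@H]1CO)C(=O)O` has not been measured in this assay. It is built from compound 2 by the same change that leads from compound 3 to compound 1, namely (amino(carboxy)methyl in place of 2-amino-2-carboxyethyl on a saturated chain carbon bound to a carbonyl carbon), at the same kind of place; the change is seen in two pairs among these compounds. Among the compounds with values here, the only guide to its effect is the measured pair, where the step of a 1.2-fold lower number from compound 3 to compound 1 (0.09 log units; within the scatter) stayed within the scatter. On that basis the expected step is a 1.1-fold lower number from compound 2 to compound 4 (0.05 log units; within the scatter), also within the scatter. Compound 4 is therefore estimated at 0.15 h in this assay. The range for compound 4 is expected to run from 0.08 h to 0.3 h.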

Compound 4, half-life: 0.535 h
The estimate for compound 4 lay 3.6-fold (0.55 log units) below the measured number, outside the stated range (above it).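

On the core of compound 2, in this assay, putting amino(carboxy)methyl in place of 2-amino-2-carboxyethyl on a saturated chain carbon bound to a carbonyl carbon gives a 3.1-fold higher number from compound 2 to compound 4 (0.50 log units; beyond the scatter), so on this core the change has a readable effect on the half-life. Set beside the earlier step, the change does not carry over unchanged from one core to the other, and the step measured on one core would not have served as a guide to the step on the other: the same change on two cores in this assay, a 1.2-fold lower number (0.09 log units; within the scatter) from compound 3 to compound 1 and a 3.1-fold higher number (0.50 log units; beyond the scatter) from compound 2 to compound 4, 3.9-fold (0.59 log units) apart, beyond the scatter of two such steps. Within the data shown here, this rests on only one pair for each core, so it shows that the outcome of the change depends on the core in these compounds, but it does not show which feature of the two cores is responsible, nor whether the same would hold for any other change or core.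

The compounds shown leave open how a longer chain than 3-amino-3-carboxypropyl would read on each core. They also leave open what an amide in place of the ester, or a chain lacking the amine or the carboxylic acid, would do to the half-life on either core.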